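A few compounds are considered here, and "the series" means these few. Any claim that something is new, unique, unknown or untested is made for them only; others in the source may bear on it.

Compound 1 `CN(C)CCCNc1nc(-c2ccc(NC(=O)Nc3ccccc3Cl)cc2)nc2ccsc12` is one of three compounds already tested in a functional assay on MDA-MB-231 cells (Homo sapiens) for cytotoxicity, read by MTT assay, with a stated time of 72 h (on this read-out higher numbers stand for weaker inhibition and lower numbers for stronger inhibition), and in that assay compound 1 gives 590 nM. Compound 2 `CN(C)CCCNc1nc(-c2ccc(NC(=O)Nc3ccc(Cl)cc3Cl)cc2)nc2ccsc12` differs from compound 1 in one place, (chloro in place of hydrogen on an aromatic carbon), and compound 2 gives 1860 nM, a change of a 3.2-fold higher number from compound 1 to compound 2 (0.50 log units; beyond the scatter). Compound 3 `CN(C)CCNc1nc(-c2ccc(NC(=O)Nc3ccccc3Cl)cc2)nc2c(Cl)c(Cl)sc12` carries a different core; how the core of compound 3 differs from that of compound 1 is not broken down here. In this assay compound 3 gives 1350 nM. Compound 4 `CN(C)CCNc1nc(-c2ccc(NC(=O)Nc3ccc(Cl)cc3Cl)cc2)nc2c(Cl)c(Cl)sc12` is not yet measured; it differs from compound 3 in the same way, (chloro in place of hydrogen on an aromatic carbon). Since that change from compound 1 to compound 2 gave a 3.2-fold higher number from compound 1 to compound 2 (0.50 log units; beyond the scatter), a step of similar size is expected from compound 3 to compound 4, about a 2.8-fold higher number from compound 3 to compound 4 (0.45 log units; beyond the scatter). Compound 4 is therefore estimated at 3800 nM, with a likely range from 1600 nM to 9000 nM.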

Compound 4, half-maximal inhibitory concentration: 3500 nM
The estimate for compound 4 lay 1.1-fold (0.04 log units) above the measured number, and the stated range covers the measured number.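

Adding the chloro group that turns 2-chlorophenyl into 2,4-dichlorophenyl again weakens inhibition in this assay, giving a 2.6-fold higher number from compound 3 to compound 4 (0.41 log units; beyond the scatter). The earlier step and this new one do not differ, so the change carries over between these two cores: the same change on two cores in this assay, a 3.2-fold higher number (0.50 log units; beyond the scatter) from compound 1 to compound 2 and a 2.6-fold higher number (0.41 log units; beyond the scatter) from compound 3 to compound 4, 1.2-fold (0.08 log units) apart, within the scatter of two such steps. For the compounds shown here, this rests on only two pairs of compounds in one cell assay, so it does not show that the step would keep its size on any other core, and it does not explain why the number rises.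

On these data alone, it remains open whether a fluoro or methoxy group in the same place would give a similar step. As far as these compounds go, it also remains open whether the step would hold with a carboxylic acid at the end of the side chain.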